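Amide cap variation on the shared core

A few compounds are considered here, and "the series" means these few. Any claim that something is new, unique, unknown or untested is made for them only; others in the source may bear on it.

Measured compounds:
compound 1 `CN(C)c1ccc(C(=O)N2CCC(NS(=O)(=O)c3cc(S(=O)(=O)c4ccccc4)ccc3C(F)(F)F)CC2)cc1` — 300 nM
compound 2 `O=C(c1cccnc1)N1CCC(NS(=O)(=O)c2cc(S(=O)(=O)c3ccccc3)ccc2C(F)(F)F)CC1` — 80 nM

In an assay on isolated protein for displacement of a labelled ligand from secreted frizzled-related protein 1 (Homo sapiens), read by fluorescence polarization, with a stated time of 30 min (a higher number here means a weaker inhibitor, a lower number a stronger inhibitor), compound 1 gives 300 nM and compound 2 gives 80 nM. Among the measured compounds shown here, compound 1 holds the highest of the two numbers; the one measured step, a 3.8-fold lower number from compound 1 to compound 2 (0.57 log units; beyond the scatter), leads away from it. Compound 3 `O=C([C@@H]1CCNC1)N1CCC(NS(=O)(=O)c2cc(S(=O)(=O)c3ccccc3)ccc2C(F)(F)F)CC1` is made from compound 1 by pyrrolidin-3-yl in place of 4-(dimethylamino)phenyl on a carbonyl carbon. For the measured compounds named here, only that single step bears on this change, since it swaps the same group on the same carbonyl carbon for another ring. Going by the values given here, it shows the carbonyl substituent can be exchanged without loss, but the group entering in compound 3 is of a different kind from the one entering in compound 2, so the direction here is uncertain. For compound 3 the expected step is a 1.5-fold lower number from compound 1 to compound 3 (0.18 log units; within the scatter), a modest move that may not exceed the scatter. Compound 3 is estimated at 200 nM, with a range from 60 nM to 700 nM.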

Compound 3, half-maximal inhibitory concentration: 60 nM
Beside the measured number, compound 3's estimate is 3.3-fold (0.52 log units) above it; the measured number falls inside the stated range.
By their numbers in this assay, from the lowest: compounds 3 and 2 (each within the scatter of the next); then compound 1.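

At the carbonyl carbon, in this assay, an aromatic ring is not needed: the non-aromatic pyrrolidin-3-yl gives a 5.0-fold lower number from compound 1 to compound 3 (0.70 log units; beyond the scatter) even with fewer heavy atoms than 4-(dimethylamino)phenyl. Replacing pyridin-3-yl with the same group gives a 1.3-fold lower number from compound 2 to compound 3 (0.12 log units; within the scatter) and so does not separate the aromatic and non-aromatic rings, which means that moving away from 4-(dimethylamino)phenyl, rather than keeping or losing aromaticity, is what these numbers register. Nothing at hand explains the difference from compound 1.

As far as these compounds go, it remains open whether the hydrogen-bond donor of pyrrolidin-3-yl or its defined stereocentre matters at this position. The opposite enantiomer, a 1-methylpyrrolidin-3-yl group or an open-chain primary amine on the same carbonyl carbon would test these points.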